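This account rests on a few compounds, and the source may have more. Where it says the series, first, only, none or still open, it means among the compounds named here.

Working notes on the alkyne series.

Compound 1 `CC#CC1=Nc2ccccc2C(C)(C)O1` and compound 2 `C#Cc1nc2ccccc2s1` have both been run in a functional assay on NCI-H522 cells (Homo sapiens) for cytotoxicity, with a stated time of 3 days; on this read-out higher numbers stand for weaker inhibition and lower numbers for stronger inhibition. In this assay compound 1 gives 8400 nM, the highest of the two numbers shown. In this assay compound 2 gives 860 nM. Compound 3 `CC#Cc1nc2ccccc2s1` sits at the limit of > 40000 nM in this assay, at which 1 of the 3 values shown sits; in this assay its entry of > 40000 nM is therefore a limit and not a number. Compound 4 `C#CC1=Nc2ccccc2C(C)(C)O1` has not yet been run in this assay.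

Compound 2 is obtained from compound 3 by hydrogen in place of methyl on a triple-bonded carbon. This change gives an at least 46-fold lower number from compound 3 to compound 2 (1.66 log units; beyond the scatter). Since the starting value is a limit, the true size of this step is only known as a floor. Compound 4 is obtained from compound 1 by hydrogen in place of methyl on a triple-bonded carbon. The surroundings of the change are the same in both pairs, so this is the same change made on two cores; among the compounds shown it occurs twice in all. The difference between the core of compound 1 and the core of compound 3 is not broken down here.

The step to compound 4 is expected to run in the same direction as the earlier one, with an estimated size of a 28-fold lower number from compound 1 to compound 4 (1.45 log units; beyond the scatter), resting on an at least 46-fold lower number from compound 3 to compound 2 (1.66 log units; beyond the scatter) and on the measured starting point of compound 1 at 8400 nM. The range is kept wide, as the earlier step is a floor. In this assay compound 4 is expected to give around 300 nM, estimated to fall between 60 nM and 2000 nM.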

Compound 4, half-maximal inhibitory concentration: 890 nM
Compound 4: the middle estimate sits 3.0-fold (0.47 log units) below what was measured, and the stated range covers the measured number.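

In this assay, replacing prop-1-yn-1-yl with ethynyl on the core of compound 1 gives a 9.4-fold lower number from compound 1 to compound 4 (0.97 log units; beyond the scatter), so the change lowers the number on both cores, and the direction carries over in the two pairs shown. The size does not carry over as a fixed amount, since the two steps differ by more than the scatter: the same change on two cores in this assay, an at least 46-fold lower number (1.66 log units; beyond the scatter) from compound 3 to compound 2 and a 9.4-fold lower number (0.97 log units; beyond the scatter) from compound 1 to compound 4, at least 4.9-fold (0.69 log units) apart, beyond the scatter of two such steps

Compound 3 is recorded at a limit and not at a number, so the step on its core is known only as a floor, and these two pairs neither give its true size nor explain why the steps differ: the limit of > 40000 nM in this assay, at which 1 of the 4 values shown sits.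

Among the compounds shown here, with only two cores, this is no general rule for the series, and the part played by the core itself remains unresolved. Also open, as far as these compounds go, is how the number would respond if the hydrogen or methyl on the triple-bonded carbon gave way to a longer chain such as ethyl or propyl, or to a hydroxymethyl or aminomethyl group, and whether the same direction would hold on a third core.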